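From Pyridin-4-yl to 6-Methoxypyridin-3-yl on a Shared Core

The source may report more compounds than this note shows. Statements on the series, on what has been measured and on what is new or still open speak of the compounds shown alone.

In an ADME assay on MT2 cells (Homo sapiens) for cytotoxicity, read by XTT assay, with a stated time of 4 days (a higher number here means that more compound is tolerated, a lower number that less compound is tolerated), compound 1 `Cc1nc2cc(-c3cccc(-c4ccccc4F)c3)nn2c(-c2cc(F)c3c(c2C)CCCO3)c1[C@H](OC(C)(C)C)C(=O)O` gives 19100 nM, and compound 2 `Cc1nc2cc(-c3cccc(-c4ccncc4)c3)nn2c(-c2cc(F)c3c(c2C)CCCO3)c1[C@H](OC(C)(C)C)C(=O)O` gives 13200 nM. Within the data shown here, compound 2 therefore has only one measured neighbour, and the two numbers lie within the scatter of each other. Compound 3 `COc1ccc(-c2cccc(-c3cc4nc(C)c([C@H](OC(C)(C)C)C(=O)O)c(-c5cc(F)c6c(c5C)CCCO6)n4n3)c2)cn1` carries 6-methoxypyridin-3-yl in place of pyridin-4-yl on an aromatic carbon. Among the measured compounds shown here, the only measured step that bears on this change is a 1.4-fold lower number from compound 1 to compound 2 (0.16 log units; within the scatter), where pyridin-4-yl stands in place of 2-fluorophenyl on an aromatic carbon. With that single exchange of aromatic groups as the guide, no step beyond the scatter is expected in this assay, and the estimate is a 1.1-fold higher number from compound 2 to compound 3 (0.03 log units; within the scatter). For compound 3 the estimated value is 14000 nM, with an expected range of 7000 nM to 27000 nM.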

Compound 3, half-maximal cytotoxic concentration: > 23000 nM
Compound 3: no number, only a limit; the forecaster's own chance of this, stated with the estimate: 10%; middle value at least 1.6-fold (0.21 log units) away from the limit.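

In this assay compound 3 gives no number, only a limit: the limit of > 23000 nM in this assay, at which 1 of the 3 values shown sits. The exchange of pyridin-4-yl for 6-methoxypyridin-3-yl is an at least 1.7-fold higher number from compound 2 to compound 3 (0.24 log units; that floor lies within the scatter), and the exchange of 2-fluorophenyl for 6-methoxypyridin-3-yl is an at least 1.2-fold higher number from compound 1 to compound 3 (0.08 log units; that floor lies within the scatter). This position, on an aromatic carbon and meta to a large group, can therefore carry a methoxy-bearing pyridine without the number falling under those of the other two compounds, but both floors lie within the scatter and the real size of either step stays unread.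

The compounds shown leave open how far past the limit compound 3 lies, and whether the methoxy group or the place of the ring nitrogen accounts for the step. They also leave open what an amine or a carboxylic acid at this position would give in this assay.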